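The source may hold more compounds than are shown below. What is called first, only, known or untested is meant among the compounds shown, and "the series" means these compounds.

In a functional assay on DU-145 cells (Homo sapiens) for inhibition, read by trypan blue exclusion, with a stated time of 96 h (on this read-out higher numbers stand for weaker inhibition of growth and lower numbers for stronger inhibition of growth), the measured compounds stand as follows:
Compound 1 `Cc1ccc(S/C(=C/c2c[nH]c3ccccc23)C(=O)c2ccc(Cl)cc2)cc1` gives 10000 nM.
Compound 2 `Cc1ccc(S/C(=C/c2ccc(Cl)cc2)C(=O)c2ccc(Cl)cc2)cc1` gives 10000 nM.
Compound 3 `Cc1ccc(S/C(=C/c2cc(C)cc(C)c2)C(=O)c2ccc(Cl)cc2)cc1` gives 50000 nM.

Compound 3 sits at the highest number of the three and is the weakest inhibitor of growth in this set: a 5.0-fold higher number from compound 1 to compound 3 (0.70 log units; beyond the scatter) and a 5.0-fold higher number from compound 2 to compound 3 (0.70 log units; beyond the scatter) both lie beyond the scatter, whereas no change at the digits printed from compound 1 to compound 2 (within the scatter). Compound 4 `Cc1ccc(S/C(=C/c2ccc[nH]2)C(=O)c2ccc(Cl)cc2)cc1` has not yet been measured. Its change from compound 3 is 1H-pyrrol-2-yl in place of 3,5-dimethylphenyl on a double-bonded chain carbon bound to a double-bonded chain carbon. The two steps that bear on it are those into compound 3, where a 1H-indol-3-yl or a 4-chlorophenyl each stood at a lower number than the 3,5-dimethylphenyl. The 1H-pyrrol-2-yl of compound 4 is nearer in kind to the 1H-indol-3-yl of compound 1 than to the 3,5-dimethylphenyl, so the expectation is a downward step in this assay of roughly the size seen in those two steps, a 3.3-fold lower number from compound 3 to compound 4 (0.52 log units; beyond the scatter). The estimated value for compound 4 is 15000 nM, with a range from 5000 nM to 50000 nM.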

Compound 4, concentration for 50% growth inhibition: 10000 nM
For compound 4 the middle estimate is 1.5-fold (0.18 log units) above the measured one, within the range that was stated.
By their numbers in this assay, from the lowest: compounds 1, 2 and 4 (each within the scatter of the next); then compound 3.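

In this assay, a five-membered aromatic ring with 1 hetero atom on the double-bonded chain carbon matches the other two groups that stand apart from 3,5-dimethylphenyl: the data show no change at the digits printed from compound 1 to compound 4 (within the scatter) and no change at the digits printed from compound 2 to compound 4 (within the scatter) at this place. Set against a 5.0-fold lower number from compound 3 to compound 4 (0.70 log units; beyond the scatter), this leaves 3,5-dimethylphenyl as the only group here that separates from the rest, while the hydrogen-bond donor entering with the 1H-pyrrol-2-yl gives no difference from 4-chlorophenyl. No measurement at hand explains why 3,5-dimethylphenyl stands apart.

Going by these compounds, whether an amine, a carboxylic acid or a longer chain at this place would take the number away from that shared by compound 1, compound 2 and compound 4 stays open. Also open, on these data alone, is whether a single methyl on the phenyl ring would already give the higher number of compound 3.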